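This account rests on a few compounds, and the source may have more. Where it says the series, first, only, none or still open, it means among the compounds named here.

Measured so far:
- compound 1 `O=C(Nc1ccc(C(F)(F)F)cc1)C1CCc2ccccc2N1`, 20300 nM
- compound 2 `O=C(Nc1ccccc1C(F)(F)F)C1CCc2ccccc2N1C(=O)c1ccc(Cl)cc1`, 786 nM

In a functional assay on PC-3 cells (Homo sapiens) for cytotoxicity, read by sulforhodamine B assay, with a stated time of 72 h (on this read-out lower numbers stand for stronger inhibition of growth and higher numbers for weaker inhibition of growth), compound 1 gives 20300 nM, the highest of the two numbers shown. Compound 2 `O=C(Nc1ccccc1C(F)(F)F)C1CCc2ccccc2N1C(=O)c1ccc(Cl)cc1` gives 786 nM in this assay, a lower number, and the two compounds differ in more than one place, so nothing more than that comparison can be drawn from them.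

Compound 3 `O=C(Nc1ccccc1)C1CCc2ccccc2N1` has not yet been measured. It differs from compound 1 in one place: hydrogen in place of trifluoromethyl on an aromatic carbon. Among the compounds with values here, no measured pair that differs only in this way is available, so the size of the step has to be guessed. Because compound 1 already gives 20300 nM, and removing a group from a weak compound rarely brings a large gain, the expected step from compound 1 to compound 3 is small and, if anything, toward a higher number: a 1.5-fold higher number from compound 1 to compound 3 (0.17 log units; within the scatter). Compound 3 is expected to give about 30000 nM in this assay, with a range from 10000 nM to 100000 nM.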

Compound 3, concentration for 50% growth inhibition: 110000 nM
Estimate against measurement, compound 3: 3.7-fold (0.56 log units) below, and the stated range ends below it.
By their numbers in this assay, from the lowest: compound 2; then compound 1; then compound 3.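

In this assay, putting hydrogen in place of trifluoromethyl on this aromatic carbon, para to a large group, brings a 5.4-fold higher number from compound 1 to compound 3 (0.73 log units; beyond the scatter). The earlier compounds shown here differ in more than one place and could not isolate this change, whereas this pair shows that the group at this position still matters in a weak compound, with trifluoromethyl going with stronger inhibition of growth than hydrogen. Nothing measured here tells what lies behind the difference.

Still open, going by these compounds, is how other groups on this carbon, such as a nitrile, an amine or a carboxylic acid, would compare with trifluoromethyl and hydrogen. Also open, on these data alone, is whether the same change would bring a step of similar size in a compound as differently built as compound 2.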